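The source may hold more compounds than are shown below. What is called first, only, known or untested is meant among the compounds shown, and "the series" means these compounds.

Compound 1 `FC(F)(F)c1ccccc1Cn1nnc2c(NC3CCCCC3)nc(-c3ccccc3)nc21` sets the starting point: in an assay on isolated protein for binding affinity to adenosine receptor A1 (Bos taurus) (a lower number here means a stronger inhibitor, a higher number a weaker inhibitor), compound 1 gives 6800000 nM. Compound 2 `Clc1ccccc1Cn1nnc2c(NC3CCCCC3)nc(-c3ccccc3)nc21` keeps everything but the substituent on the benzyl ring, (chloro in place of trifluoromethyl on an aromatic carbon), and in this assay compound 2 gives 34000000 nM, a step of a 5.0-fold higher number from compound 1 to compound 2 (0.70 log units; beyond the scatter). Compound 3 `FC(F)(F)c1ccccc1Cn1nnc2c(NC3CCCC3)nc(-c3ccccc3)nc21` instead changes the amine side, (cyclopentyl in place of cyclohexyl on a nitrogen on an aromatic ring), and in this assay compound 3 gives 600000 nM, which is an 11-fold lower number from compound 1 to compound 3 (1.05 log units; beyond the scatter) and the lowest of the three numbers.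

Compound 4 `Clc1ccccc1Cn1nnc2c(NC3CCCC3)nc(-c3ccccc3)nc21` has not yet been measured in this assay. It differs from compound 3 by chloro in place of trifluoromethyl on an aromatic carbon, the same change that was made from compound 1 to compound 2, now on the core of compound 3 rather than that of compound 1, the two cores differing by cyclopentyl in place of cyclohexyl on a nitrogen on an aromatic ring. Among the measured compounds shown here, since the one earlier example of this change gave a 5.0-fold higher number from compound 1 to compound 2 (0.70 log units; beyond the scatter), compound 4 is expected to show a step of about a 5.0-fold higher number from compound 3 to compound 4 (0.70 log units; beyond the scatter) in this assay. On that basis compound 4 is estimated at 3000000 nM, with a plausible range from 1200000 nM to 8000000 nM.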

Compound 4, inhibition constant: 9000000 nM
Compound 4: middle estimate off by 3.0-fold (0.48 log units), on the low side; the whole stated range lies below it.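

In this assay, chloro in place of trifluoromethyl raises the number on both cores, but the step now seen, a 15-fold higher number from compound 3 to compound 4 (1.18 log units; beyond the scatter), is larger than on the core of compound 1, so the direction carries over and the size does not: the same change on two cores in this assay, a 5.0-fold higher number (0.70 log units; beyond the scatter) from compound 1 to compound 2 and a 15-fold higher number (1.18 log units; beyond the scatter) from compound 3 to compound 4, 3.0-fold (0.48 log units) apart, beyond the scatter of two such steps The same four compounds read the other way show cyclopentyl in place of cyclohexyl lowering the number on both cores, with a 3.8-fold lower number from compound 2 to compound 4 (0.58 log units; beyond the scatter) as the smaller of the two steps: the same change on two cores in this assay, an 11-fold lower number (1.05 log units; beyond the scatter) from compound 1 to compound 3 and a 3.8-fold lower number (0.58 log units; beyond the scatter) from compound 2 to compound 4, 3.0-fold (0.48 log units) apart, beyond the scatter of two such steps This shows that in this series the two changes do not add up independently, yet with only these four compounds it cannot show why, nor whether the shared direction would hold on any further core.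

The compounds shown leave open how a methyl, a methoxy group or a nitrile would behave in place of chloro or trifluoromethyl on the benzyl ring. They also leave open whether a cyclobutyl ring or an open alkyl chain on the amine nitrogen would continue the trend seen from cyclohexyl to cyclopentyl.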